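This account rests on a few compounds, and the source may have more. Where it says the series, first, only, none or still open, it means among the compounds named here.

Working notes on the series.

Two members of this series have been measured in a physicochemical assay for lipophilicity; a lower number here means a more polar compound, a higher number a more lipophilic compound. Compound 1, `CCCCCCCCCCNC(=O)Oc1ccc(Cl)cc1C(=O)Nc1ccc(Cl)c(Cl)c1`, gives 7.77 in this assay. Compound 2, `CCCCCNC(=O)Oc1ccc(Cl)cc1C(=O)Nc1ccc(Cl)cc1`, gives 5.11 in this assay and so stands as the lower of the two numbers, with compound 1 the nearer and the only other point, a gap well beyond the scatter. For the measured compounds named here, compound 1 and compound 2 differ in more than one place, so their two values can only be set side by side and no single step is read from them.

Compound 3, `CCCCCCCCCCNC(=O)Oc1ccc(Cl)cc1C(=O)Nc1ccc(Cl)cc1`, is not yet measured in this assay. It differs from compound 2 in one place: pentyl in place of hydrogen on a saturated chain carbon, five bonds along the chain from an amide-type nitrogen. With no measured step of this kind in the series, the expectation rests on the value of compound 2 and on the size of the group that enters. A step upward, beyond the scatter, is expected, since the entering pentyl adds five carbon atoms to the chain without donors, acceptors or charge. The step from compound 2 to compound 3 is expected to be a number 2.19 log units higher from compound 2 to compound 3 (beyond the scatter). Compound 3 is therefore estimated at 7.3 in this assay, with a range from 6.6 to 8.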

Compound 3, partition coefficient: 7.19
Estimate against measurement, compound 3: 0.11 log units above; the range from low to high includes it.
By their numbers in this assay, from the lowest: compound 2; then compound 3; then compound 1.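

In this assay, the chain position now has its first measured single-place step: pentyl in place of hydrogen on a saturated chain carbon, five bonds along the chain from an amide-type nitrogen, gives a number 2.08 log units higher from compound 2 to compound 3 (beyond the scatter). The same result supplies a second single-place step, since hydrogen in place of chloro on an aromatic carbon gives a number 0.58 log units lower from compound 1 to compound 3 (beyond the scatter), so the two changes that could only be seen together in the earlier pair can now be read apart, with the chain change the larger step of the two. No measurement is at hand that offers a reason for either step.

As far as these compounds go, each change is seen only once and in a single setting, so it remains open whether the pentyl step would be of similar size on a chain carrying a different aromatic substitution, or whether the size of the step follows chain length through propyl or octyl. From the compounds shown here alone, it is also open how a chain ending in an amine or a carboxylic acid would stand against the plain chains here.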